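A few compounds are considered here, and "the series" means these few. Any claim that something is new, unique, unknown or untested is made for them only; others in the source may bear on it.

Of the compounds shown here, three have been measured in a functional assay on NCI-H460 cells (Homo sapiens) for inhibition, read by sulforhodamine B assay, with a stated time of 48 h; a higher number here means a weaker inhibitor of growth, a lower number a stronger inhibitor of growth. Compound 1 `COc1ccc(C(=O)C2=CCCCc3c2cc(OC)c(OC)c3OC)c(O)c1O` gives > 10000 nM, which is a limit of the assay and not a number. Compound 2 `COc1ccc2c(c1O)CCCC=C2c1cc(OC)c(OC)c(OC)c1` gives 0.028 nM. Compound 3 `COc1ccc2c(c1)CCCC(c1cc(OC)c(OC)c(OC)c1)=C2` gives 470 nM, the higher of the two true numbers, and its distance from compound 2 lies far beyond the scatter.

The next compound, compound 4 `COc1ccc2c(c1O)CCCC(c1cc(OC)c(OC)c(OC)c1)=C2`, departs from compound 3 in a single place: hydroxy in place of hydrogen on an aromatic carbon. In words, a hydroxy takes the place of a hydrogen on an aromatic carbon, ortho to a methoxy group. Among the compounds with values here, the only guide to this change is indirect. Compound 2, at 0.028 nM, also carries a hydroxy on an aromatic carbon, whereas compound 3 carries none, but these two compounds differ in more than that one place. Compound 1 also carries hydroxy groups and goes against any simple reading.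

A lower number is nevertheless expected in this assay, with a drop beyond the scatter, estimated as a 12-fold lower number from compound 3 to compound 4 (1.07 log units; beyond the scatter). Closing the whole gap to compound 2 is not expected. For compound 4 the estimated value is 40 nM, with an expected range from 3 nM to 500 nM.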

Compound 4, concentration for 50% growth inhibition: 1200 nM
Estimate against measurement, compound 4: 30-fold (1.48 log units) below, outside the stated range (above it).
By their numbers in this assay, from the lowest: compound 2; then compound 3; then compound 4. At a limit, above all of these: compound 1.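

In this assay, within the data shown here, hydroxy in place of hydrogen on this aromatic carbon, ortho to a methoxy group, gives a 2.6-fold higher number from compound 3 to compound 4 (0.41 log units; beyond the scatter), which is the first direct reading of this change at this position, and it points to a modestly weaker inhibitor of growth rather than a stronger one. On the core of compound 3, then, a hydroxy at this carbon does not lower the number, which runs against the indirect hint from compound 2, a compound that also carries a hydroxy on an aromatic carbon but differs from compound 3 in more than that one place. Nothing available here gives a reason for this step.

From the compounds shown here alone, this is one step at one position on one core, so it remains open whether the same change would move the number in the same direction on the core of compound 2. Going by these compounds, it also remains open whether an amine or a fluorine on this aromatic carbon would follow the hydroxy or part from it.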